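Removing One Methyl From Compound 2

The source may report more compounds than this note shows. Statements on the series, on what has been measured and on what is new or still open speak of the compounds shown alone.

In an ADME assay on HEK293 cells (Homo sapiens) for cytotoxicity, read by MTT assay, with a stated time of 48 h (on this read-out lower numbers stand for stronger inhibition and higher numbers for weaker inhibition), compound 1 (`O=C1/C(=C\c2ccc([N+](=O)[O-])cc2)S/C(=N/c2ccccc2)N1Cc1ccncc1`) gives 250000 nM and compound 2 (`COc1ccc(/C=C2/S/C(=N/c3ccccc3)N(Cc3ccncc3)C2=O)cc1OC`) gives 171000 nM. Within the data shown here, these are the only two numbers available, and they lie within the scatter of each other, so compound 2 has no clear place apart from compound 1. Among the measured compounds shown here, the one measured step, a 1.5-fold lower number from compound 1 to compound 2 (0.16 log units; within the scatter), comes with 3,4-dimethoxyphenyl in place of 4-nitrophenyl on a double-bonded chain carbon bound to a double-bonded ring carbon.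

Compound 3 (`COc1cc(/C=C2/S/C(=N/c3ccccc3)N(Cc3ccncc3)C2=O)ccc1O`) differs from compound 2 by hydrogen in place of methyl on an oxygen on an aromatic ring, which turns 3,4-dimethoxyphenyl into 4-hydroxy-3-methoxyphenyl. For the measured compounds named here, no measured pair tests methoxy to hydroxy directly. Going by the values given here, the only guide is the exchange of the whole group in a 1.5-fold lower number from compound 1 to compound 2 (0.16 log units; within the scatter), and that step stayed within the scatter. A change beyond the scatter in this assay is therefore not expected, in either direction. The estimated step is a 1.1-fold lower number from compound 2 to compound 3 (0.03 log units; within the scatter). Compound 3 is expected to give about 160000 nM, with an estimated range from 85000 nM to 300000 nM.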

Compound 3, half-maximal inhibitory concentration: 67400 nM
The estimate for compound 3 lay 2.4-fold (0.38 log units) above the measured number; the measured number lies below the stated range.
By their numbers in this assay, from the lowest: compound 3; then compounds 2 and 1 (each within the scatter of the next).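

On this read-out, the aromatic ring's substituents first separate beyond the scatter at this oxygen: in this assay, hydrogen in place of methyl gives a 2.5-fold lower number from compound 2 to compound 3 (0.40 log units; beyond the scatter). The exchange of a single methyl thus does what the swap of the whole group between compound 1 and compound 2 did not, and the wider replacement of 4-nitrophenyl by 4-hydroxy-3-methoxyphenyl gives a 3.7-fold lower number from compound 1 to compound 3 (0.57 log units; beyond the scatter), which leaves compound 3 with the lowest number of the three, though the steps are modest and the number remains high. No measurement shown here explains why removing this methyl lowers the number.

Going by these compounds, what remains open is whether the free hydroxy itself matters or whether any group smaller than methoxy on this oxygen would serve, which an amine or a fluorine in place of the hydroxy, or an ethyl in place of the methyl, could help to separate. The compounds shown also leave open whether the remaining methoxy of 4-hydroxy-3-methoxyphenyl contributes to the number, and whether a carboxylic acid on the aromatic ring would move it further in either direction.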